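Step from compound 2 to compound 3 in this series

The source may hold more compounds than are shown below. What is called first, only, known or untested is meant among the compounds shown, and "the series" means these compounds.

Compound 2 `c1ccc(-c2nnc(SCCCN3CCN(c4nc5ccccc5o4)CC3)o2)cc1` holds the lowest of the two numbers in a functional assay on A-431 cells (Homo sapiens) for inhibition, read by MTT assay, with a stated time of 72 h (on this read-out higher numbers stand for weaker inhibition and lower numbers for stronger inhibition), at 57600 nM; compound 1 `Brc1ccc(-c2nnc(SCCCN3CCN(c4nc5ccccc5o4)CC3)o2)cc1` gives 57800 nM, and the step of a 1.0-fold lower number from compound 1 to compound 2 (0.00 log units; within the scatter) lies within the scatter. Compound 3 `c1ccc(-c2nnc(SCCCN3CCN(c4nc5ccccc5s4)CC3)o2)cc1` differs from compound 2 by 1,3-benzothiazol-2-yl in place of 1,3-benzoxazol-2-yl on an amine nitrogen in a ring. Among the compounds with values here, no measured step touches this change; the single step known, hydrogen in place of bromo on an aromatic carbon, sits elsewhere and stayed within the scatter. For compound 3 the expected step is a 1.0-fold lower number from compound 2 to compound 3 (0.00 log units; within the scatter), nothing beyond the scatter. Compound 3 is therefore estimated at 57000 nM, within 25000 nM to 130000 nM.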

Compound 3, half-maximal inhibitory concentration: 93400 nM
The estimate for compound 3 lay 1.6-fold (0.21 log units) below the measured number, within the range that was stated.
By their numbers in this assay, from the lowest: compounds 2, 1 and 3 (each within the scatter of the next).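

In this assay, within the data shown here, the first change on the amine nitrogen in a ring, 1,3-benzothiazol-2-yl in place of 1,3-benzoxazol-2-yl, gives a 1.6-fold higher number from compound 2 to compound 3 (0.21 log units; within the scatter). This position therefore accepts this exchange of one fused group for the other without a step beyond the scatter, as the hydrogen-for-bromo step did elsewhere in the series. Nothing at hand bears on the reason for this result.

Open, going by these compounds, is whether a pyridin-2-yl or a plain phenyl on the same nitrogen would move the number beyond the scatter. A longer chain to the sulfur is equally untested in the compounds shown here.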